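Fluoro to Methoxy: Expected Cytotoxicity of Compound 3

The source may hold more compounds than are shown below. What is called first, only, known or untested is meant among the compounds shown, and "the series" means these compounds.

Of the compounds shown here, two sharing one core have been tested in an ADME assay on MT4 cells (Homo sapiens) for cytotoxicity, read by MTT assay, with a stated time of 5 days; on this read-out higher numbers stand for lower toxicity in this test and lower numbers for higher toxicity in this test. Compound 1 `COc1cc2nc([S+]([O-])CC(=O)Nc3ccc(C(F)(F)F)cc3)nc(Nc3c(C)cc(/C=C/C#N)cc3C)c2cc1OC` gives 52200 nM, and compound 2 `COc1cc2nc([S+]([O-])CC(=O)Nc3cccc(F)c3)nc(Nc3c(Cl)cc(/C=C/C#N)cc3Cl)c2cc1OC` gives 9550 nM. Of these two numbers, compound 2 stands lowest, and the gap to compound 1 is beyond the usual scatter of this assay, so compound 2 is the more toxic of the pair in this test.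

Compound 3 `COc1cccc(NC(=O)C[S+]([O-])c2nc(Nc3c(Cl)cc(/C=C/C#N)cc3Cl)c3cc(OC)c(OC)cc3n2)c1` has not yet been measured. It differs from compound 2 in one place: methoxy in place of fluoro on an aromatic carbon. Among the compounds with values here, no measured pair in this set shows what this change alone does, so the expectation must be cautious. A step from compound 2 to compound 3 of about a 1.3-fold higher number from compound 2 to compound 3 (0.10 log units; within the scatter) is expected, which is within the scatter. Compound 3 is therefore estimated to give 12000 nM in this assay, with a range of 4000 nM to 40000 nM.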

Compound 3, half-maximal cytotoxic concentration: >= 167000 nM
Compound 3 ended at the assay's limit; the forecaster's own chance of this, stated with the estimate: 5%; middle value at least 13-fold (1.14 log units) from the limit.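

In this assay, replacing fluoro with methoxy at this one place, on an aromatic carbon meta to a large group, gives an at least 17-fold higher number from compound 2 to compound 3 (1.24 log units; beyond the scatter). Compound 1 and compound 2 differ in more than one place, so they could not show that this single change, from 3-fluorophenyl to 3-methoxyphenyl, can shift the read-out so strongly. Compound 3 stands at a limit, not at a number, so this step is a floor and its true size stays unknown: the limit of >= 167000 nM in this assay, at which 1 of the 3 values shown sits.

Among the compounds shown, only fluoro and methoxy can be compared at this place, so it remains open how a hydroxyl, an amine or a longer chain such as ethoxy would behave there. From the compounds shown here alone, it also remains open whether the same change would give a similar step with the other groups of compound 1 in place.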